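The source may report more compounds than this note shows. Statements on the series, on what has been measured and on what is new or still open speak of the compounds shown alone.

Working notes on the series. In a functional assay on NCI-H520 cells (Homo sapiens) for cytotoxicity (a higher number here means a weaker inhibitor of growth, a lower number a stronger inhibitor of growth), compound 1 `CSc1ccc(C2=C(c3ccc(O)cc3)C(=O)N3CCCC3C2)cc1` gives > 100000 nM, which is a limit of the assay and not a number. Within the data shown here, compound 2 `CSc1ccc(C2=C(c3ccc(Br)cc3)C(=O)N3CCCC3C2)cc1` gives 7000 nM, the only true number so far.

Compound 3 `CSc1ccc(C2=C(c3ccc(F)cc3)C(=O)N3CCCC3C2)cc1` carries fluoro in place of bromo on an aromatic carbon, para to a large group: fluoro in place of bromo on an aromatic carbon.

Among the measured compounds shown here, one measured step bears on this carbon: an at least 14-fold lower number from compound 1 to compound 2 (1.15 log units; beyond the scatter), a large step beyond the scatter, with bromo in place of hydroxy. It shows that the group here can move the number strongly, but it is a single step resting on a limit. A moderate move in this assay towards a higher number is expected, smaller than that step. The expected step is a 2.1-fold higher number from compound 2 to compound 3 (0.33 log units; beyond the scatter). For compound 3 the estimate is 15000 nM, with an expected range of 5000 nM to 50000 nM.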

Compound 3, concentration for 50% growth inhibition: 250 nM
Compound 3: the middle estimate sits 60-fold (1.78 log units) above what was measured; measured number outside the range, below it.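

In this assay, the change from 4-bromophenyl to 4-fluorophenyl gives a 28-fold lower number from compound 2 to compound 3 (1.45 log units; beyond the scatter), so this aromatic carbon responds strongly to an exchange between two halogens and not only to the loss of hydroxy, and compound 3 is the strongest inhibitor of growth of the three. Fluoro in place of hydroxy gives an at least 400-fold lower number from compound 1 to compound 3 (2.60 log units; beyond the scatter), the widest step in the series so far. The value of compound 1 is a limit of the assay and not a number, so the true size of that step stays unknown: the limit of > 100000 nM in this assay, at which 1 of the 3 values shown sits.

Chloro, methoxy, nitrile or an amine on this carbon would show whether fluoro stands alone here or belongs to a wider set of groups. Three compounds varied at one carbon, read in one assay, support no trend across groups.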